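The source may report more compounds than this note shows. Statements on the series, on what has been measured and on what is new or still open speak of the compounds shown alone.

Measured compounds:
compound 1 `CCCOC(=O)/C=C/c1ccc(NC(=O)C2(NC(=O)c3ccc4c(C5CCCC5)c(-c5ncc(Cl)cn5)n(C)c4c3)CCC2)cc1OCC`: 0.35 h
compound 2 `CCOc1cc(NC(=O)C2(NC(=O)c3ccc4c(C5CCCC5)c(-c5ncc(Cl)cn5)n(C)c4c3)CCC2)ccc1/C=C/C(=O)OCc1ccccc1`: 2.17 h

Going by the values given here, in an ADME assay (liver) for pharmacokinetics, with Liver microsome (Rattus norvegicus) as the target, using microsomes (on this read-out higher numbers stand for a longer-lived compound and lower numbers for a shorter-lived compound), compound 1 gives the lowest of the two numbers known, with compound 2 standing a 6.2-fold higher number from compound 1 to compound 2 (0.79 log units; beyond the scatter). Compound 3 `CCOc1cc(NC(=O)C2(NC(=O)c3ccc4c(C5CCCC5)c(-c5ncc(Cl)cn5)n(C)c4c3)CCC2)ccc1/C=C/C(=O)OCCOCCOC` differs from compound 1 in one place: 2-methoxyethoxy in place of methyl on a saturated chain carbon, two bonds along the chain from an oxygen next to a carbonyl group. Among the compounds with values here, the only measured step, a 6.2-fold higher number from compound 1 to compound 2 (0.79 log units; beyond the scatter), changed the same ester chain, but with a different group, so it guides the direction more than the size. A modest rise is therefore expected, namely a 2.0-fold higher number from compound 1 to compound 3 (0.30 log units; within the scatter). For compound 3 the expected half-life is 0.7 h, within a range from 0.25 h to 2 h.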

Compound 3, half-life: 1.07 h
Beside the measured number, compound 3's estimate is 1.5-fold (0.18 log units) below it; low and high end bracket the measured number.
By their numbers in this assay, from the lowest: compound 1; then compound 3; then compound 2.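

In this assay, going by these compounds alone, phenyl is not the only change on this ester chain that goes with a longer half-life: the ringless 2-methoxyethoxy in place of methyl does so too, with a 3.1-fold higher number from compound 1 to compound 3 (0.49 log units; beyond the scatter). The ester chain carrying phenyl still gives the longest half-life of the set, with a 2.0-fold lower number from compound 2 to compound 3 (0.31 log units; beyond the scatter). Nothing available explains these differences. 

Still open, going by these compounds, is how an ester chain ending in an amine would behave, or a carboxylic acid in place of the ester, in this assay.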